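The source may report more compounds than this note shows. Statements on the series, on what has been measured and on what is new or still open speak of the compounds shown alone.

Measured so far:
- Compound 1, `Cc1nc(C(=O)Nc2cccc(NC(=O)COc3ccc4c(=O)ccoc4c3)c2)cs1`: 473 nM
- Compound 2, `Cc1cc(C(=O)Nc2cccc(NC(=O)COc3ccc4c(=O)ccoc4c3)c2)no1`: 68 nM

Both compounds share one core and differ only in the ring attached to the carbonyl carbon. In an assay on isolated protein for inhibition of Rho-associated protein kinase 1 (Homo sapiens), read by scintillation counting, radiometric assay and 33P incorporation, with a stated time of 40 min, in the presence of a further agent that is not named here (on this read-out lower numbers stand for stronger inhibition and higher numbers for weaker inhibition), compound 1 gives 473 nM, while compound 2 gives 68 nM. For the measured compounds named here, the single measured step, a 7.0-fold lower number from compound 1 to compound 2 (0.84 log units; beyond the scatter), shows that swapping one small heteroaromatic ring for another at that position can move the read-out beyond the scatter. Going by the values given here, compound 2 therefore stands with the lowest number of the two, with compound 1 as its only neighbour.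

Compound 3, `NCc1ccc(C(=O)Nc2cccc(NC(=O)COc3ccc4c(=O)ccoc4c3)c2)cc1`, carries the change (4-(aminomethyl)phenyl in place of 5-methyl-1,2-oxazol-3-yl on a carbonyl carbon). Among the compounds with values here, no measured step covers this change, so the step from compound 1 to compound 2 serves only as a rough guide to how much this position can matter. The number for compound 3 is expected to lie near that of compound 2, with wide uncertainty, an expected step of a 2.2-fold higher number from compound 2 to compound 3 (0.34 log units; beyond the scatter). The estimate for compound 3 is 150 nM, with a range from 30 nM to 800 nM.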

Compound 3, half-maximal inhibitory concentration: 532 nM
Compound 3: middle estimate off by 3.5-fold (0.55 log units), on the low side; low and high end bracket the measured number.
By their numbers in this assay, from the lowest: compound 2; then compounds 1 and 3 (each within the scatter of the next).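

In this assay, a step of a 7.8-fold higher number from compound 2 to compound 3 (0.89 log units; beyond the scatter) shows that 4-(aminomethyl)phenyl on this carbonyl carbon does not keep the level of 5-methyl-1,2-oxazol-3-yl, so the position responds to a change of ring size as well as to a swap between five-membered rings. For the compounds shown here, a step of a 1.1-fold higher number from compound 1 to compound 3 (0.05 log units; within the scatter) shows that this six-membered ring of carbon only and 2-methyl-1,3-thiazol-4-yl read alike here, which leaves 5-methyl-1,2-oxazol-3-yl as the one group of the three that stands apart. Nothing available explains why these groups read as they do.

Whether the aminomethyl nitrogen matters remains open, since plain phenyl is not among the compounds shown. From the compounds shown here alone, it is also open whether the gain comes from the 1,2-oxazole ring or its methyl group, which an unsubstituted 1,2-oxazol-3-yl group would separate.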